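This account rests on a few compounds, and the source may have more. Where it says the series, first, only, none or still open, it means among the compounds named here.

Working notes on the series.

Going by the values given here, compound 1 `COC[C@H]1CN(c2ccc(CCCO)cc2)C(=O)O1` gives 1.27 in a physicochemical assay for lipophilicity (a lower number here means a more polar compound, a higher number a more lipophilic compound), the lowest of the two numbers so far. Its nearest neighbour is compound 2 `COC[C@H]1CN(c2ccc(OCCCCO)cc2)C(=O)O1`, which gives 1.84 in this assay. Among the compounds with values here, the only measured step in the set is the one with 4-hydroxybutoxy in place of 3-hydroxypropyl on an aromatic carbon: a number 0.57 log units higher from compound 1 to compound 2 (beyond the scatter).

The next compound, compound 3 `COC[C@H]1CN(c2ccc(OCCC(C)=O)cc2)C(=O)O1`, differs from compound 1 in one place: 2-acetylethoxy in place of 3-hydroxypropyl on an aromatic carbon. Within the data shown here, the step to compound 2 bears on this change only in part, since it also replaces the hydroxypropyl by an oxygen-linked chain, and it went modestly up; no measured step in the set swaps a hydroxyl for a ketone. Among the measured compounds shown here, with only that one step to lean on, the expectation is a rise in this assay comparable to the one seen for compound 2, with a wider band of uncertainty.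

For compound 3 the estimated step is a number 0.73 log units higher from compound 1 to compound 3 (beyond the scatter). Compound 3 is therefore expected to give about 2 in this assay, within a range from 1.6 to 2.4.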

Compound 3, partition coefficient: 1.37
For compound 3 the middle estimate is 0.63 log units above the measured one, and the stated range ends above it.
By their numbers in this assay, from the lowest: compounds 1 and 3 (each within the scatter of the next); then compound 2.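

The change from 3-hydroxypropyl to 2-acetylethoxy on this aromatic carbon gives a number 0.10 log units higher from compound 1 to compound 3 (within the scatter), so in this assay the larger chain, with 6 heavy atoms against 4, cannot be told apart from the smaller one. The oxygen-linked chains do not read alike here: acetyl in place of 2-hydroxyethyl on a saturated chain carbon gives a number 0.47 log units lower from compound 2 to compound 3 (beyond the scatter), so the rise given by a number 0.57 log units higher from compound 1 to compound 2 (beyond the scatter) does not carry over to every oxygen-linked chain at this position, and compound 3 goes against any such rule. No measurement at hand accounts for either step.

Compound 2 differs from compound 1 in both the chain and its link to the aromatic ring, and compound 3 does the same, so the shares of the oxygen link, the chain length and the chain end cannot be separated. From the compounds shown here alone, how this assay would read for a chain ending in a carboxylic acid or an amine, or for a longer chain carrying the acetyl, remains open.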